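Aniline variation on a shared core: towards compound 4

This account rests on a few compounds, and the source may have more. Where it says the series, first, only, none or still open, it means among the compounds named here.

Measured so far in a functional assay on K562 cells (Homo sapiens) for antiproliferative activity, read by CCK-8 assay, with a stated time of 72 h; a lower number here means a stronger inhibitor, a higher number a weaker inhibitor:
compound 1 `Cc1cc(Nc2cc(N3CCN(C)CC3)nc(Nc3cccc(Cl)c3)n2)n[nH]1` gives 97.2 nM
compound 2 `Cc1cc(Nc2cc(N3CCN(C)CC3)nc(Nc3cccc([N+](=O)[O-])c3)n2)n[nH]1` gives 138 nM
compound 3 `Cc1cc(Nc2cc(N3CCN(C)CC3)nc(Nc3ccc(C#N)cc3)n2)n[nH]1` gives 58.1 nM

Compound 2 holds the highest of the three numbers in this assay. Its nearest neighbour is compound 1, with a 1.4-fold higher number from compound 1 to compound 2 (0.15 log units; within the scatter), a gap within the scatter, so no order between the two can be read. The furthest is compound 3, with a 2.4-fold lower number from compound 2 to compound 3 (0.38 log units; beyond the scatter), a modest step beyond the scatter.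

Compound 4 `Cc1cc(Nc2cc(N3CCN(C)CC3)nc(Nc3ccc(S(N)(=O)=O)cc3)n2)n[nH]1` has not yet been measured. It differs from compound 2 in one place: 4-sulfamoylphenyl in place of 3-nitrophenyl on a nitrogen on an aromatic ring.

Of the measured steps, the one that bears most directly on this change is a 2.4-fold lower number from compound 2 to compound 3 (0.38 log units; beyond the scatter), which also exchanged the 3-nitrophenyl for a 4-cyanophenyl on a nitrogen on an aromatic ring. The related step of a 1.7-fold lower number from compound 1 to compound 3 (0.22 log units; within the scatter) stayed within the scatter. Among the measured compounds shown here, no measured compound carries a 4-sulfamoylphenyl, so the step to compound 4 is read by analogy with compound 3 alone, and a modest lower number is expected, a 1.8-fold lower number from compound 2 to compound 4 (0.26 log units; within the scatter), with a range wide enough to admit no change beyond the scatter.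

Compound 4 is therefore estimated at 75 nM, expected to fall between 30 nM and 200 nM.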

Compound 4, half-maximal inhibitory concentration: 1430 nM
Compound 4: the middle estimate sits 19-fold (1.28 log units) below what was measured; the measured number lies above the stated range.
By their numbers in this assay, from the lowest: compounds 3, 1 and 2 (each within the scatter of the next, the first and the last beyond it); then compound 4.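

Among the compounds shown here, at this place on the shared core, 4-sulfamoylphenyl is the first group in this assay to produce a large step, with a 10-fold higher number from compound 2 to compound 4 (1.02 log units; beyond the scatter) and a 15-fold higher number from compound 1 to compound 4 (1.17 log units; beyond the scatter) against only small or modest differences among the earlier three compounds. The sharpest contrast is a 25-fold higher number from compound 3 to compound 4 (1.39 log units; beyond the scatter) and comes from sulfamoyl in place of cyano on an aromatic carbon, so the tolerance seen with the 4-cyanophenyl of compound 3 does not extend to every group on that ring. Compared with the 3-nitrophenyl, the 4-sulfamoylphenyl adds a sulfur atom and a hydrogen-bond donor, but no data on hand tie the loss to either difference or to any other cause.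

Still open, as far as these compounds go, is whether the loss follows the sulfamoyl group specifically or extends to other groups at the same place on the phenyl ring. A methylsulfonyl group, which keeps the sulfur and both oxygens but has no amide-type hydrogens, would test this most directly, while a carboxylic acid or an amine would show how far the result extends to other groups.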